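A few compounds are considered here, and "the series" means these few. Any claim that something is new, unique, unknown or untested is made for them only; others in the source may bear on it.

Three compounds share one core and differ only in the group that sits on its aromatic carbon. Compound 1 `CN1CCN(CCCN(C(=O)Nc2ccc(F)c(Cl)c2)C2CCc3cc(Br)ccc3C2)CC1` gives 180 nM in an assay on CHO cells for binding affinity to melanin-concentrating hormone receptor 1 (Homo sapiens); a lower number here means a stronger inhibitor, a higher number a weaker inhibitor. Compound 2 `COc1ccc2c(c1)CCC(N(CCCN1CCN(C)CC1)C(=O)Nc1ccc(F)c(Cl)c1)C2` gives 190 nM, and the change a 1.1-fold higher number from compound 1 to compound 2 (0.02 log units; within the scatter) shows that a swap of this group can leave the number unchanged. Compound 3 `CNS(=O)(=O)c1ccc2c(c1)CC(N(CCCN1CCN(C)CC1)C(=O)Nc1ccc(F)c(Cl)c1)CC2` gives 3000 nM, the highest of the three numbers, and its distance from compound 1 and from compound 2 lies beyond the scatter.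

Compound 4 `CC(C)C(=O)Nc1ccc2c(c1)CC(N(CCCN1CCN(C)CC1)C(=O)Nc1ccc(F)c(Cl)c1)CC2` carries the change ((isopropylcarbonyl)amino in place of methylsulfamoyl on an aromatic carbon). Going by the values given here, no measured step covers this exchange: the only measured step swaps a bromo for a methoxy, a change that stayed within the scatter, and it says nothing about swapping a sulfonamide-type group for an amide-type group. What the numbers do show is that compound 3, with its methylsulfamoyl group, stands far above compound 1 and compound 2, so the group at this position clearly matters here. Because compound 3 sits at 3000 nM, there is room in both directions. The expectation is a modest step of a 2.0-fold lower number from compound 3 to compound 4 (0.30 log units; within the scatter) towards a lower number, with wide uncertainty. Compound 4 is therefore estimated at 1500 nM, within a range from 400 nM to 6000 nM.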

Compound 4, inhibition constant: 61 nM
The estimate for compound 4 lay 25-fold (1.39 log units) above the measured number; the whole stated range lies above it.
By their numbers in this assay, from the lowest: compound 4; then compounds 1 and 2 (each within the scatter of the next); then compound 3.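

In this assay, replacing methylsulfamoyl with (isopropylcarbonyl)amino gives a 49-fold lower number from compound 3 to compound 4 (1.69 log units; beyond the scatter), so a change of group at this aromatic carbon can move the number far more than the earlier swap of bromo for methoxy, a 1.1-fold higher number from compound 1 to compound 2 (0.02 log units; within the scatter), had shown. The high number of compound 3 therefore does not mean that a larger group on this carbon must do poorly: compound 4, at 61 nM, now comes first in the order of numbers, ahead of compounds 1 and 2, even though its group has more heavy atoms than methylsulfamoyl. Both groups count one hydrogen-bond donor and carry no net charge, so those two counts do not separate them, and nothing available explains the gap between the two compounds.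

The compounds shown leave open whether the low number of compound 4 depends on the carbonyl-and-nitrogen link itself or on its isopropyl end. An acetylamino group would test the role of that end by replacing isopropyl with methyl, while a plain amino group on the same carbon would show what remains without the carbonyl and the isopropyl end.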